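Moving one hydroxyl from ortho to para on a pyridine triaryl

This account rests on a few compounds, and the source may have more. Where it says the series, first, only, none or still open, it means among the compounds named here.

Compound 3 `Oc1ccc(-c2cc(-c3ccccc3O)nc(-c3ccccc3O)c2)cc1` is known only as a limit in an ADME assay on HEK293 cells (Homo sapiens) for cytotoxicity, read by CCK-8 assay, with a stated time of 4 days; on this read-out lower numbers stand for stronger inhibition and higher numbers for weaker inhibition: it gives > 50000 nM, which is the limit of > 50000 nM in this assay, at which 1 of the 3 values shown sits, and not a measured number. Its neighbours in this assay are compound 2 `Oc1ccc(-c2cc(-c3ccc(O)cc3)nc(-c3cccc(O)c3)c2)cc1`, which gives 840 nM, and compound 1 `Oc1ccc(-c2cc(-c3ccccc3O)cc(-c3ccccc3O)n2)cc1`, which gives 6990 nM. Compound 4 `Oc1ccc(-c2cc(-c3ccc(O)cc3)nc(-c3ccccc3O)c2)cc1` differs from compound 3 by 4-hydroxyphenyl in place of 2-hydroxyphenyl on an aromatic carbon. For the measured compounds named here, no measured step of this kind is available, so the expectation rests on the gap between compound 3 and compound 2. Compound 4 is expected to move toward the number of compound 2, with a step of an at least 3.3-fold lower number from compound 3 to compound 4 (0.52 log units; beyond the scatter) in this assay. The estimate for compound 4 is 15000 nM, expected between 3000 nM and 60000 nM.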

Compound 4, half-maximal inhibitory concentration: 26300 nM
For compound 4 the middle estimate is 1.8-fold (0.24 log units) below the measured one, within the range that was stated.
By their numbers in this assay, from the lowest: compound 2; then compound 1; then compound 4. At a limit, above all of these: compound 3.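

In this assay, the change next to the ring nitrogen gives an at least 1.9-fold lower number from compound 3 to compound 4 (0.27 log units; that floor lies within the scatter), and compound 3 is known only as a limit, so this step does not show a real fall: the limit of > 50000 nM in this assay, at which 1 of the 4 values shown sits. Far larger is a 31-fold higher number from compound 2 to compound 4 (1.50 log units; beyond the scatter), where 2-hydroxyphenyl replaces 3-hydroxyphenyl, while a 3.8-fold higher number from compound 1 to compound 4 (0.58 log units; beyond the scatter) is modest. Replacing one 2-hydroxyphenyl group with 4-hydroxyphenyl therefore does not reach the low number of compound 2, which carries 3-hydroxyphenyl at this place. Open, as far as these compounds go, is how far compound 3 truly lies from compound 4, and whether an amine or a carboxylic acid on this ring would keep the number of compound 2.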